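Swapping the fluorophenyl for a pyridyl at the ring nitrogen

A few compounds are considered here, and "the series" means these few. Any claim that something is new, unique, unknown or untested is made for them only; others in the source may bear on it.

In a functional assay on CHO-K1 cells with Glucose-dependent insulinotropic receptor (Homo sapiens) as the target, read by a luciferase reporter, with a stated time of 5 h (on this read-out higher numbers stand for larger maximal responses and lower numbers for smaller maximal responses), compound 1 `CC(C)OC(=O)N1CCC(Oc2ncnc3c2CCN3c2ccc(S(C)(=O)=O)cc2F)CC1` gives 91%, the second highest of the three numbers. Compound 2 `CC(C)OC(=O)N1CCC(Oc2ncnc3c2CCN3c2ccc(-c3nccs3)cc2F)CC1` gives 74% and compound 3 `CC(C)SC(=O)N1CCC(Oc2ncnc3c2CCN3c2ccc(S(C)(=O)=O)cc2F)CC1` gives 138% in this assay. Compound 4 `CC(C)OC(=O)N1CCC(Oc2ncnc3c2CCN3c2ccc(S(C)(=O)=O)nc2)CC1` differs from compound 1 as follows: 6-(methylsulfonyl)pyridin-3-yl in place of 2-fluoro-4-(methylsulfonyl)phenyl on a nitrogen on an aromatic ring in a ring. Among the measured compounds shown here, no measured step alters this ring itself. The nearest comparison is a number 17 percentage points lower from compound 1 to compound 2 (beyond the scatter), a modest change on the same aromatic ring, while a number 47 percentage points higher from compound 1 to compound 3 (beyond the scatter) concerns the carbamate and does not bear on it. A small lowering or no change beyond the scatter is therefore expected in this assay, that is a number 11 percentage points lower from compound 1 to compound 4 (beyond the scatter). Compound 4 is estimated at 80%, with a range from 55% to 110%.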

Compound 4, largest response reached (reported as percent of maximum), in percent of the reference or control that the assay uses: 97%
For compound 4 the middle estimate is 17 percentage points below the measured one; the measured number falls inside the stated range.
By their numbers in this assay, from the lowest: compound 2; then compounds 1 and 4 (each within the scatter of the next); then compound 3.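

In this assay the whole aromatic group on the ring nitrogen proves exchangeable, with a number 6 percentage points higher from compound 1 to compound 4 (within the scatter) for 6-(methylsulfonyl)pyridin-3-yl in place of 2-fluoro-4-(methylsulfonyl)phenyl. The earlier step on this group replaced only the methylsulfonyl, whereas here the methylsulfonyl stays, the fluorine leaves and a ring nitrogen enters. Nothing available explains this result. Going by these compounds, it remains open whether the pyridine ring would give a similar response alongside the isopropylsulfanyl carbonyl of compound 3, and whether an amine could stand in place of its methylsulfonyl.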